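Series notes: step from compound 3 to compound 4

The source may report more compounds than this note shows. Statements on the series, on what has been measured and on what is new or still open speak of the compounds shown alone.

Measured compounds:
compound 1 `COc1ccc(C(=O)c2cc(OC)c(OC)c(OC)c2)cc1NC(=O)/C=C/c1cc(OC)c(OC)c(OC)c1`, in a functional assay on PC-3 cells (Homo sapiens) for cytotoxicity, read by MTT assay, with a stated time of 72 h (on this read-out higher numbers stand for weaker inhibition and lower numbers for stronger inhibition), compound 1 gives 3900 nM
compound 2 `COc1cccc(/C=C/C(=O)Nc2cc(C(=O)c3cc(OC)c(OC)c(OC)c3)ccc2OC)c1`, in this assay compound 2 gives 4700 nM
compound 3 `COc1ccc(C(=O)c2cc(OC)c(OC)c(OC)c2)cc1NC(=O)/C=C/c1cccc(OC(F)(F)F)c1`, in this assay compound 3 gives 7700 nM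

Compound 3 sits at the upper end of the three numbers, but its gaps to the other two, a 2.0-fold higher number from compound 1 to compound 3 (0.30 log units; within the scatter) and a 1.6-fold higher number from compound 2 to compound 3 (0.21 log units; within the scatter), are both within the scatter, so the three compounds cannot be told apart on these data.

Compound 4 `COc1ccc(C(=O)c2cc(OC)c(OC)c(OC)c2)cc1NC(=O)/C=C/c1ccc(N)cc1` is not yet measured. It differs from compound 3 in one place: 4-aminophenyl in place of 3-(trifluoromethoxy)phenyl on a double-bonded chain carbon bound to a double-bonded chain carbon.

The measured steps that bear on this are those at the same place, a 1.2-fold higher number from compound 1 to compound 2 (0.08 log units; within the scatter) and a 2.0-fold higher number from compound 1 to compound 3 (0.30 log units; within the scatter), together with a 1.6-fold higher number from compound 2 to compound 3 (0.21 log units; within the scatter); each of them stayed within the scatter. Among the measured compounds shown here, no measured step brings in a hydrogen-bond donor at this place, so the present change is less well covered. Still, since every exchange at this place has left this assay unchanged beyond the scatter, no step beyond the scatter is expected here either, that is a 1.5-fold lower number from compound 3 to compound 4 (0.19 log units; within the scatter) is expected. For compound 4 the estimate in this assay is 5000 nM, within a range from 1500 nM to 16000 nM.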

Compound 4, half-maximal inhibitory concentration: 15900 nM
Beside the measured number, compound 4's estimate is 3.2-fold (0.50 log units) below it, within the range that was stated.
By their numbers in this assay, from the lowest: compounds 1, 2 and 3 (each within the scatter of the next); then compound 4.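

In this assay, among the compounds shown here, 4-aminophenyl gives the first exchange at this place to go beyond the scatter, and it does so against all three earlier groups: 3-(trifluoromethoxy)phenyl (a 2.1-fold higher number from compound 3 to compound 4 (0.31 log units; beyond the scatter)), 3-methoxyphenyl (a 3.4-fold higher number from compound 2 to compound 4 (0.53 log units; beyond the scatter)) and 3,4,5-trimethoxyphenyl (a 4.1-fold higher number from compound 1 to compound 4 (0.61 log units; beyond the scatter)). For the compounds shown here, the place on a double-bonded chain carbon is therefore not indifferent to every exchange, since compounds 1, 2 and 3 stay within the scatter of one another while compound 4, the one compound here with a hydrogen-bond donor in this group, stands apart with a higher number, meaning weaker inhibition. Nothing available accounts for this step.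

The compounds shown leave open whether a hydroxyl, a dimethylamino or an acetamido group on this phenyl ring would stay with compounds 1, 2 and 3 or go with compound 4. They also leave open how an unsubstituted phenyl would read, and whether moving the amine elsewhere on the ring would change the number.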